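The compounds below may be only part of what the source reports. "The series", "measured", "known", "first", "only" and "open" are said of these compounds alone.

Of the compounds shown here, three sharing one core have been measured in a functional assay on MCF7 cells (Homo sapiens) for cytotoxicity, read by MTT assay, with a stated time of 48 h; a lower number here means a stronger inhibitor, a higher number a weaker inhibitor. Compound 1 `COc1cc(-c2nnc3n2NC(c2ccco2)C(C(=O)c2ccccc2C)S3)cc(OC)c1OC` gives 69900 nM. Compound 2 `COc1cc(C(=O)C2Sc3nnc(-c4cc(OC)c(OC)c(OC)c4)n3NC2c2ccco2)cc(OC)c1OC` returns the limit of the assay, > 100000 nM, and not a number. Compound 3 `COc1cc(-c2nnc3n2NC(c2ccco2)C(C(=O)c2ccccc2F)S3)cc(OC)c1OC` gives 94800 nM, the highest of the two numbers shown, though its nearest neighbour is compound 1 and the step of a 1.4-fold higher number from compound 1 to compound 3 (0.13 log units; within the scatter) lies within the scatter.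

Compound 4 `COc1cc(-c2nnc3n2NC(c2ccco2)C(C(=O)c2ccc(C(F)(F)F)cc2)S3)cc(OC)c1OC` has not yet been measured. It differs from compound 3 at the carbonyl carbon: 4-(trifluoromethyl)phenyl in place of 2-fluorophenyl on a carbonyl carbon. Among the measured compounds shown here, three measured steps touch that same group on the carbonyl carbon. The step of an at least 1.4-fold higher number from compound 1 to compound 2 (0.15 log units; that floor lies within the scatter) runs up to the limit (the limit of > 100000 nM in this assay, at which 1 of the 3 values shown sits), the step of an at least 1.0-fold lower number from compound 2 to compound 3 (0.02 log units; that floor lies within the scatter) comes back from it, and the step of a 1.4-fold higher number from compound 1 to compound 3 (0.13 log units; within the scatter) stays within the scatter. None of these changes moved the number beyond the scatter. In this assay the step of a 1.0-fold higher number from compound 3 to compound 4 (0.00 log units; within the scatter) is therefore expected to be small, with a real chance of another limit. Compound 4 is estimated at 95000 nM, within a range of 40000 nM to 200000 nM.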

Compound 4, half-maximal inhibitory concentration: 33600 nM
For compound 4 the middle estimate is 2.8-fold (0.45 log units) above the measured one, and the stated range ends above it.
By their numbers in this assay, from the lowest: compound 4; then compounds 1 and 3 (each within the scatter of the next). At a limit, above all of these: compound 2.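

In this assay, among the compounds shown here, 4-(trifluoromethyl)phenyl on the carbonyl carbon gives the first change at this position that moves the number beyond the scatter, both against 2-fluorophenyl (a 2.8-fold lower number from compound 3 to compound 4 (0.45 log units; beyond the scatter)) and against 2-methylphenyl (a 2.1-fold lower number from compound 1 to compound 4 (0.32 log units; beyond the scatter)). Compound 4 also stands apart from the 3,4,5-trimethoxyphenyl compound (an at least 2.9-fold lower number from compound 2 to compound 4 (0.47 log units; beyond the scatter)), though that step gives only a floor. Compound 2 remains a limit of the assay and not a number: the limit of > 100000 nM in this assay, at which 1 of the 4 values shown sits.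

The change swaps both the substituent and where it sits on the phenyl ring, so the compounds shown cannot separate the two, and a 4-fluorophenyl or 2-(trifluoromethyl)phenyl group would be needed to do so. On these data alone, it also stays open whether a group of another kind on the phenyl ring, such as an amine or a carboxylic acid, would lower the number further.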